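A few compounds are considered here, and "the series" means these few. Any claim that something is new, unique, unknown or untested is made for them only; others in the source may bear on it.

Compound 1 `CC(O)C1=CC(=O)c2ccccc2C1=O` and compound 2 `O=C(C1=CC(=O)c2ccccc2C1=O)c1cccc(F)c1` share the same core and differ in the group attached to it. For the measured compounds named here, in a functional assay on WHCO1 cells (Homo sapiens) for cytotoxicity, read by MTT assay, with a stated time of 24 h (a higher number here means a weaker inhibitor, a lower number a stronger inhibitor), compound 1 gives 6400 nM, the lowest of the two numbers measured so far. In this assay compound 2 gives 94800 nM, a gap beyond the usual scatter, so compound 1 is the stronger inhibitor of the pair. Compound 3 `O=C1C=C(C(O)c2cccc(Cl)c2)C(=O)c2ccccc21` has not yet been measured. It differs from compound 1 in a single place: 3-chlorophenyl in place of methyl on a saturated chain carbon bound to a double-bonded ring carbon and an oxygen on a saturated carbon. Going by the values given here, compound 2 also carries a halogen-bearing aromatic ring, joined to the core through a carbonyl rather than through a hydroxyl-bearing carbon; no single step from compound 2 to either other compound is known, only its own number. The step is expected to be a 2.3-fold higher number from compound 1 to compound 3 (0.37 log units; beyond the scatter), toward a weaker inhibitor. Compound 3 is estimated at 15000 nM, with a range from 4000 nM to 60000 nM.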

Compound 3, half-maximal inhibitory concentration: 7300 nM
For compound 3 the middle estimate is 2.1-fold (0.31 log units) above the measured one; measured number inside the range.
By their numbers in this assay, from the lowest: compounds 1 and 3 (each within the scatter of the next); then compound 2.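

In this assay the swap of methyl for 3-chlorophenyl on the saturated chain carbon gives a 1.1-fold higher number from compound 1 to compound 3 (0.06 log units; within the scatter) and so leaves the two compounds within the usual scatter. For the compounds shown here, this is the first step that can be read at this position, and it shows that, for this pair, a much larger group carrying an aromatic ring can replace methyl there without a measurable change in this cell read-out. No measurement shown explains this result.

The compounds shown leave open whether the chlorine contributes anything, since a plain phenyl group would be needed to separate it from the ring. They also leave open how an amine or a longer chain would behave on the same carbon, and whether the oxygen on that carbon matters.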